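This account rests on a few compounds, and the source may have more. Where it says the series, first, only, none or still open, it means among the compounds named here.

In a functional assay on HCT-116 cells (Homo sapiens) for antiproliferative activity, read by MTT assay, with a stated time of 24 h (on this read-out higher numbers stand for weaker inhibition and lower numbers for stronger inhibition), compound 1 `COc1cccc(C(=O)Oc2ccc3c(=O)c(-c4cc(OC)c(OC)cc4OC)coc3c2)c1` gives > 10000 nM, which is a limit of the assay and not a number. Compound 2 `COc1cc(OC)c(-c2coc3cc(OCc4ccccc4C#N)ccc3c2=O)cc1OC` also gives only a limit, > 10000 nM. The evidence so far comes down to this: the limit of > 10000 nM in this assay, at which 2 of the 2 values shown sit. Compound 3 `COc1cc(OC)c(-c2coc3cc(OCc4ccccc4Cl)ccc3c2=O)cc1OC` keeps the rest of compound 2 and changes one group: chloro in place of cyano on an aromatic carbon. Chloro takes the place of cyano on an aromatic carbon, ortho to a large group. Among the compounds with values here, the only measured step, a step that the two limits leave unreadable from compound 1 to compound 2, puts 2-cyanobenzyl in place of (3-methoxyphenyl)carbonyl, and its size cannot be read. It therefore offers no size to carry over, so no change beyond the scatter is expected in this assay. The estimated step, a step that the limit leaves unreadable from compound 2 to compound 3, is expected to be small, and another limit is likely. For compound 3 the estimate is 15000 nM, with an expected range from 4000 nM to 40000 nM.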

Compound 3, half-maximal inhibitory concentration: 2450 nM
Beside the measured number, compound 3's estimate is 6.1-fold (0.79 log units) above it; measured number below the stated range.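

Swapping cyano for chloro at this spot, ortho to a large group, is the first change shown to have a readable effect: this assay records an at least 4.0-fold lower number from compound 2 to compound 3 (0.61 log units; beyond the scatter). Replacing the (3-methoxyphenyl)carbonyl group on the oxygen with 2-chlorobenzyl likewise gives an at least 4.0-fold lower number from compound 1 to compound 3 (0.61 log units; beyond the scatter), so a group on this oxygen can go with measurable antiproliferative activity on the shared core. Going by these compounds, both steps start from a limit of the assay, so their full sizes remain unknown, and the step between the two limits cannot be read at all.

On these data alone, whether chloro is special at this spot stays open, as fluoro, bromo, methyl or methoxy in its place could give a weaker, similar or stronger result. The picture also still rests largely on limits: the limit of > 10000 nM in this assay, at which 2 of the 3 values shown sit.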